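The source may hold more compounds than are shown below. What is called first, only, known or untested is meant among the compounds shown, and "the series" means these compounds.

Compound 2 `CN1CCC(=C(F)c2cccc(NC(=O)c3ccc(Cl)cc3F)n2)CC1` is one of two compounds for which a number is known in an ADME assay on the whole organism (Rattus norvegicus, strain Sprague-Dawley) for pharmacokinetics, read by LC-MS, with a stated time of 24 h, at a dose of 5 mg/kg by the oral route; a higher number here means more compound in the circulation at the dose given, a lower number less compound in the circulation. In this assay, among the measured compounds shown here, compound 2 gives 105 ng.h/mL, and the other measured compound, compound 1 `CN1CCC(=C(F)c2cccc(NC(=O)c3ccc(F)cn3)n2)CC1`, gives 121 ng.h/mL, so the two numbers sit within the scatter of each other; the one measured step, a 1.2-fold lower number from compound 1 to compound 2 (0.06 log units; within the scatter), exchanged the whole aromatic group attached to the carbonyl carbon and left the number essentially unchanged. Compound 3 `CN1CCC(=C(F)c2cccc(NC(=O)c3ccc(Cl)cc3)n2)CC1` differs from compound 2 by hydrogen in place of fluoro on an aromatic carbon. For the measured compounds named here, no measured step removes a fluoro from this ring, and the only step known changed far more than this while staying within the scatter, so no movement beyond the scatter is expected in this assay, with a 1.0-fold higher number from compound 2 to compound 3 (0.02 log units; within the scatter) as the expected step. Compound 3 is therefore estimated at 110 ng.h/mL, between 45 ng.h/mL and 270 ng.h/mL.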

Compound 3, area under the concentration-time curve: 151 ng.h/mL
Beside the measured number, compound 3's estimate is 1.4-fold (0.14 log units) below it, within the range that was stated.
By their numbers in this assay, from the lowest: compounds 2, 1 and 3 (each within the scatter of the next).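

In this assay, among the compounds shown here, hydrogen in place of fluoro on the aromatic carbon ortho to a large group gives a 1.4-fold higher number from compound 2 to compound 3 (0.16 log units; within the scatter), so this single atom, which the earlier compounds never varied on its own, does not move the number beyond the scatter. The 4-chlorophenyl group also stays within the scatter of the 5-fluoropyridin-2-yl group, with a 1.2-fold higher number from compound 1 to compound 3 (0.10 log units; within the scatter), so all three aromatic groups on the carbonyl carbon now lie within the scatter of one another. No measurement at hand bears on these results.

The compounds shown leave open whether an amine or a carboxylic acid in place of the chloro group would move the number in this assay beyond the scatter. They also leave open whether changes to the shared core, rather than to this aromatic group, would do so.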